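The compounds below may be only part of what the source reports. "The series", "measured", "known", "first", "only" and "open" are said of these compounds alone.

The shared core is seen in compound 1 `O=C(Nc1ccc(Cl)c(-c2nnc3c(Cl)cccn23)c1)c1ccc(Cl)cc1Cl` and compound 2 `O=C(Nc1ccc(Cl)c(-c2nnc3c(Cl)cccn23)c1)c1ccccc1`. In a functional assay on AN3-CA cells (Homo sapiens) for antiproliferative activity, read by MTT assay, with a stated time of 72 h (a higher number here means a weaker inhibitor, a lower number a stronger inhibitor), compound 1 gives 84800 nM, and in this assay compound 2 gives 67600 nM. The step of a 1.3-fold lower number from compound 1 to compound 2 (0.10 log units; within the scatter) shows that swapping the group on the carbonyl carbon left the number essentially where it was. Among the compounds with values here, compound 2 therefore stands at the lowest of the two numbers so far, with compound 1 nearest and not separated from it beyond the scatter. Compound 3 `CS(=O)(=O)c1cccc(C(=O)Nc2ccc(Cl)c(-c3nnc4c(Cl)cccn34)c2)c1` differs from compound 2 by methylsulfonyl in place of hydrogen on an aromatic carbon. Within the data shown here, the only measured step bears on this position indirectly, and it was within the scatter, so no step beyond the scatter is expected in this assay. The number for compound 3 is estimated at 60000 nM, within a range of 20000 nM to 150000 nM, which corresponds to an expected step of a 1.1-fold lower number from compound 2 to compound 3 (0.05 log units; within the scatter).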

Compound 3, half-maximal inhibitory concentration: > 100000 nM
Compound 3: only a limit was reported; the forecaster's own chance of this, stated with the estimate: 30%; at least 1.6-fold (0.22 log units) between middle value and limit.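

In this assay compound 3 is reported only as a limit, > 100000 nM. Methylsulfonyl on this aromatic carbon, meta to a large group, gives an at least 1.4-fold higher number from compound 2 to compound 3 (0.17 log units; that floor lies within the scatter), and 3-(methylsulfonyl)phenyl in place of 2,4-dichlorophenyl gives an at least 1.1-fold higher number from compound 1 to compound 3 (0.07 log units; that floor lies within the scatter); both floors lie within the scatter, so neither change is shown to exceed it, although neither brought the number lower. Compound 3 is the only compound shown that sits at this limit: the limit of > 100000 nM in this assay, at which 1 of the 3 values shown sits.

Going by these compounds, how far the true number for compound 3 lies past the limit remains open. So does whether an amine or a carboxylic acid on the same aromatic carbon would give a measurable number, which would show whether the result belongs to methylsulfonyl or to this place on the ring.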